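Cyclic Amines on the Ring Nitrogen: Compound 4

A few compounds are considered here, and "the series" means these few. Any claim that something is new, unique, unknown or untested is made for them only; others in the source may bear on it.

Going by the values given here, compound 3 `CN1CCC(Cn2nc(Cc3ccc(Cl)cc3)c3ccccc3c2=O)C1` gives 79.4 nM in an assay for binding affinity to Alpha-1B adrenergic receptor (Homo sapiens) (on this read-out lower numbers stand for stronger inhibition and higher numbers for weaker inhibition), the lowest of the three numbers so far; compound 2 `CN1CCCCC(n2nc(Cc3ccc(Cl)cc3)c3ccccc3c2=O)C1` gives 158 nM, and compound 1 `CN(C)CCn1nc(Cc2ccc(Cl)cc2)c2ccccc2c1=O` gives 200 nM. The step of a 2.5-fold lower number from compound 1 to compound 3 (0.40 log units; beyond the scatter) is modest but beyond the scatter, whereas a 2.0-fold lower number from compound 2 to compound 3 (0.30 log units; within the scatter) and a 1.3-fold lower number from compound 1 to compound 2 (0.10 log units; within the scatter) both lie within it. Compound 4 `CN1CCC(n2nc(Cc3ccc(Cl)cc3)c3ccccc3c2=O)CC1` differs from compound 3 by 1-methylpiperidin-4-yl in place of (1-methylpyrrolidin-3-yl)methyl on an aromatic nitrogen. The steps that bear on this change are a 2.0-fold lower number from compound 2 to compound 3 (0.30 log units; within the scatter) and a 2.5-fold lower number from compound 1 to compound 3 (0.40 log units; beyond the scatter): exchanges among these amine-bearing groups have moved the read-out little, at most modestly. Compound 4 is therefore expected to show a step of a 1.1-fold higher number from compound 3 to compound 4 (0.05 log units; within the scatter), within the scatter. Compound 4 is estimated at 90 nM, with a range of 40 nM to 200 nM.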

Compound 4, inhibition constant: 6.31 nM
Beside the measured number, compound 4's estimate is 14-fold (1.15 log units) above it; measured number outside the range, below it.
By their numbers in this assay, from the lowest: compound 4; then compounds 3, 2 and 1 (each within the scatter of the next, the first and the last beyond it).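

At this aromatic nitrogen, 1-methylpiperidin-4-yl stands apart from the other three amine-bearing groups in this assay, with a 13-fold lower number from compound 3 to compound 4 (1.10 log units; beyond the scatter) and a 25-fold lower number from compound 2 to compound 4 (1.40 log units; beyond the scatter) and a 32-fold lower number from compound 1 to compound 4 (1.50 log units; beyond the scatter) as its steps. Compound 3 and compound 4 hold the same atoms, joined differently. This position responds strongly to how those atoms are joined, not only to which atoms are present. As far as these compounds go, it remains open whether a piperidin-4-yl carrying a benzyl group or only hydrogen on its ring nitrogen would keep this number. No evidence here accounts for the size of these steps.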